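A Methoxy Group Relocated on the Carbonyl Aryl Ring

This account rests on a few compounds, and the source may have more. Where it says the series, first, only, none or still open, it means among the compounds named here.

Three compounds sharing one core differ in the aryl group on the carbonyl. In a functional assay on HeLa cells (Homo sapiens) for antiproliferative activity, read by cell counting, with a stated time of 2 days (on this read-out lower numbers stand for stronger inhibition and higher numbers for weaker inhibition), compound 1 `COc1ccc(Nc2nc(N)c(C(=O)c3ccc(Cl)cc3)s2)cc1` gives 83 nM and compound 2 `COc1ccc(Nc2nc(N)c(C(=O)c3ccc(OC)c(OC)c3)s2)cc1` gives 52 nM while compound 3 `COc1ccc(Nc2nc(N)c(C(=O)c3ccccc3OC)s2)cc1` gives 17 nM as the lowest number of the three, with its gaps to both others beyond the scatter. Compound 4 `COc1ccc(Nc2nc(N)c(C(=O)c3cccc(OC)c3)s2)cc1` carries 3-methoxyphenyl in place of 2-methoxyphenyl on a carbonyl carbon. For the measured compounds named here, the one measured step close to this change is a 4.9-fold lower number from compound 1 to compound 3 (0.69 log units; beyond the scatter) and it is modest, brought by 2-methoxyphenyl in place of 4-chlorophenyl. Going by the values given here, no measured compound carries 3-methoxyphenyl, so that step offers only a rough scale. Since compound 3 already holds the lowest number at 17 nM a modest rise in this assay is expected rather than a further fall. The expected change is a 2.4-fold higher number from compound 3 to compound 4 (0.37 log units; beyond the scatter) and would be smaller than the measured step. For compound 4 the estimate is 40 nM with an expected range from 13 nM to 120 nM around it.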

Compound 4, half-maximal inhibitory concentration: 37 nM
For compound 4 the middle estimate is 1.1-fold (0.03 log units) above the measured one, within the range that was stated.
By their numbers in this assay, from the lowest: compound 3; then compounds 4, 2 and 1 (each within the scatter of the next, the first and the last beyond it).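

Moving the methoxy group on the carbonyl aryl ring, with the same atoms joined differently, gives a 2.2-fold higher number from compound 3 to compound 4 (0.34 log units; beyond the scatter) in this assay and so shows that its place on the ring alone shifts the number, in favour of 2-methoxyphenyl over 3-methoxyphenyl. Taking away the second methoxy group of the dimethoxyphenyl ring, with hydrogen in its place, gives a 1.4-fold lower number from compound 2 to compound 4 (0.15 log units; within the scatter) and so leaves the two compounds level. The change from 4-chlorophenyl to 3-methoxyphenyl gives a 2.2-fold lower number from compound 1 to compound 4 (0.35 log units; beyond the scatter) and shows that a single methoxy group at this second place also beats the chlorinated ring, though by less than the 2-methoxyphenyl ring's printed value suggests.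

Going by these compounds, whether 2-ethoxyphenyl or 2-aminophenyl on the carbonyl would match compound 3 remains open. Nothing available explains why the place of the methoxy group matters.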